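Aryl swap on the long-chain hydroxypiperidine chromone series

The source may hold more compounds than are shown below. What is called first, only, known or untested is meant among the compounds shown, and "the series" means these compounds.

Measured so far:
compound 1 `O=c1cc(-c2ccccc2)oc2cccc(OCCCN3CCC(O)CC3)c12` — 125 nM
compound 2 `O=c1cc(-c2ccccc2Cl)oc2ccc(OCCCCCCN3CCC(O)CC3)cc12` — 47 nM

In an assay on isolated protein (Cavia porcellus) with Sigma non-opioid intracellular receptor 1 (Homo sapiens) as the target, read by radioligand binding (a lower number here means a stronger inhibitor, a higher number a weaker inhibitor), compound 2 gives the lower of the two numbers; compound 1 sits at the higher one, a gap beyond the scatter. Compound 3 `O=c1cc(-c2ccc(F)cc2)oc2ccc(OCCCCCCN3CCC(O)CC3)cc12` differs from compound 2 in one place: 4-fluorophenyl in place of 2-chlorophenyl on an aromatic carbon. Within the data shown here, no measured pair isolates this change, so the step has no precedent here; the expectation is a step of about the scatter or less in this assay, in either direction, written as a 1.4-fold higher number from compound 2 to compound 3 (0.14 log units; within the scatter). Compound 3 is therefore estimated at 65 nM, within 20 nM to 220 nM.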

Compound 3, half-maximal inhibitory concentration: 95 nM
Beside the measured number, compound 3's estimate is 1.5-fold (0.16 log units) below it, within the range that was stated.
By their numbers in this assay, from the lowest: compound 2; then compounds 3 and 1 (each within the scatter of the next).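

In this assay, 4-fluorophenyl in place of 2-chlorophenyl on the aromatic carbon next to the ring oxygen gives a 2.0-fold higher number from compound 2 to compound 3 (0.31 log units; beyond the scatter), so this position responds to a change of aryl group, though modestly. This single step changes both the halogen and its place on the phenyl ring, and the two effects cannot be separated. Nothing at hand explains the step.

Still open, as far as these compounds go, is how 4-chlorophenyl or 2-fluorophenyl would read on this long chain, which would separate halogen from placement. Also open, from the compounds shown here alone, is whether a methoxy or nitrile substituent on that phenyl ring would read differently from a halogen.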